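Replacing a Diethylamide with a Propylamide in Rat Paw Edema

The source may hold more compounds than are shown below. What is called first, only, known or untested is meant among the compounds shown, and "the series" means these compounds.

Compound 2 `CCN(CC)C(=O)CC1CCc2cc(OC)c(OC)cc21` stands higher of the two measured compounds: in a functional assay on the whole organism (strain Wistar) for inhibition, with Rattus norvegicus as the target, read by paw edema, with stated times of 60 min and 3 h, at a dose of 100 mg/kg by the oral route (a higher number here means more inhibition at the dose given (going by the name of the read-out), a lower number less inhibition), compound 2 gives 37.7%, while compound 1 `COc1cc2c(cc1OC)C(CC(=O)O)CC2` gives 27.5%. Within the data shown here, the one measured step, a number 10.2 percentage points higher from compound 1 to compound 2 (beyond the scatter), put diethylamino in place of hydroxy on the carbonyl carbon. Compound 3 `CCCNC(=O)CC1CCc2cc(OC)c(OC)cc21` differs from compound 2 by propylamino in place of diethylamino on a carbonyl carbon. Among the measured compounds shown here, no measured step exchanges one amino group for another, so the single known step is only a loose guide, and a change within the scatter is expected. The estimate for compound 3 is 33%, between 20% and 46%. That corresponds to an expected step of a number 4.7 percentage points lower from compound 2 to compound 3 (within the scatter).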

Compound 3, a percentage reported as inhibition, in the whole organism at one dose (the size of the read-out at that dose, not a potency): 29%
The estimate for compound 3 lay 4 percentage points above the measured number; low and high end bracket the measured number.
By their numbers in this assay, from the lowest: compounds 1, 3 and 2 (each within the scatter of the next, the first and the last beyond it).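

In this assay, propylamino in place of diethylamino on the carbonyl carbon gives a number 8.7 percentage points lower from compound 2 to compound 3 (within the scatter), so this exchange of amino groups cannot be told apart from repeat scatter. Against the acid, propylamino in place of hydroxy gives a number 1.5 percentage points higher from compound 1 to compound 3 (within the scatter), so amide formation at this position does not by itself separate a compound from compound 1 beyond the scatter. Nothing here explains these numbers. As far as these compounds go, how a ring amine such as piperidine or a longer chain such as butylamino would read on this carbonyl carbon remains open.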